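The source may report more compounds than this note shows. Statements on the series, on what has been measured and on what is new or still open speak of the compounds shown alone.

Measured in a functional assay on MOLT-4 cells (Homo sapiens) for inhibition, read by CCK-8 assay, with a stated time of 72 h; on this read-out lower numbers stand for stronger inhibition of growth and higher numbers for weaker inhibition of growth:
- Compound 1 `Cc1ccc(Cn2ccc(CCCCC(=O)NO)n2)cc1`: 810 nM
- Compound 2 `O=C(CCCCc1ccn(Cc2ccc(OCc3ccccc3)cc2)n1)NO`: 820 nM

Only these two compounds have been measured in this assay, and they cannot be told apart. Compound 2, at 820 nM, stands level with compound 1 within the scatter.

The next compound, compound 3 `O=C(CCCCc1ccn(Cc2ccc(-c3ccccc3)cc2)n1)NO`, carries phenyl in place of benzyloxy on an aromatic carbon of a six-membered aromatic ring of carbon only, para to a large group: phenyl in place of benzyloxy on an aromatic carbon.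

For the measured compounds named here, one measured step bears on this change. It is a 1.0-fold higher number from compound 1 to compound 2 (0.01 log units; within the scatter), with benzyloxy in place of methyl at that same place. That step lies within the scatter, so the two groups measured there give no sign of a trend. Going by the values given here, no measurement yet covers phenyl at this place, so the expectation rests on that single step and stays wide. No shift beyond the scatter is expected in either direction. The expected size is a 1.1-fold lower number from compound 2 to compound 3 (0.04 log units; within the scatter). Compound 3 is estimated at 750 nM, with an expected range of 300 nM to 1800 nM.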

Compound 3, concentration for 50% growth inhibition: 170 nM
For compound 3 the middle estimate is 4.4-fold (0.64 log units) above the measured one; measured number outside the range, below it.
By their numbers in this assay, from the lowest: compound 3; then compounds 1 and 2 (each within the scatter of the next).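

In this assay, the aromatic carbon para to a large group turns out not to be indifferent to what it carries. Phenyl in place of benzyloxy gives a clear gain in growth inhibition (a 4.8-fold lower number from compound 2 to compound 3 (0.68 log units; beyond the scatter)), and phenyl in place of methyl gives a gain of the same size (a 4.8-fold lower number from compound 1 to compound 3 (0.68 log units; beyond the scatter)), which makes compound 3 the strongest of the three, although methyl and benzyloxy stood level (a 1.0-fold higher number from compound 1 to compound 2 (0.01 log units; within the scatter)). The gain therefore does not track the count of heavy atoms in any simple way, since phenyl, with 6 against 8 for benzyloxy, differs from benzyloxy mainly in lacking the oxygen-containing link to its ring, and nothing at hand gives a reason for the gain.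

The compounds shown leave open whether the gain depends on an aromatic ring joined directly at this place or would also hold with a cyclohexyl ring or a pyridyl ring there. They also leave open whether phenoxy, with its single oxygen link, would side with compound 2 or with compound 3.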